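Swapping the cyanophenyl on compound 3's pyrrole nitrogen

The compounds below may be only part of what the source reports. "The series", "measured", "known", "first", "only" and "open" are said of these compounds alone.

This account follows a series built around the shared core of compound 1 `O=C(COc1cccc(Cl)c1)NC1CCN(Cc2ccc3[nH]ccc3c2)CC1`, which in an assay on HEK293 cells for displacement of a labelled ligand from melanin-concentrating hormone receptor 1 (Homo sapiens) (a lower number here means a stronger inhibitor, a higher number a weaker inhibitor), gives 2340 nM. Compound 2 `O=C(COc1cccc(Cl)c1)NC1CCN(Cc2cccc(-n3cccc3)c2)CC1` gives 297 nM in this assay. Compound 3 `N#Cc1ccc(-n2ccc(CN3CCC(NC(=O)COc4cccc(Cl)c4)CC3)c2)cc1` gives 52 nM in this assay, the lowest of the three numbers, clearly separated from both compound 2 and compound 1. The next step leads to compound 4 `O=C(COc1cccc(Cl)c1)NC1CCN(Cc2ccn(-c3ccon3)c2)CC1`, which differs from compound 3 only in this respect: 1,2-oxazol-3-yl in place of 4-cyanophenyl on an aromatic nitrogen. Among the measured compounds shown here, with no measured pair showing what this change does, the expectation rests on compound 3 alone, and the step of a 3.8-fold higher number from compound 3 to compound 4 (0.59 log units; beyond the scatter) is estimated to be a moderate loss, beyond the scatter. In this assay compound 4 is therefore expected to give about 200 nM, within a range of 60 nM to 700 nM.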

Compound 4, half-maximal inhibitory concentration: 1500 nM
Beside the measured number, compound 4's estimate is 7.5-fold (0.88 log units) below it, outside the stated range (above it).
By their numbers in this assay, from the lowest: compound 3; then compound 2; then compounds 4 and 1 (each within the scatter of the next).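

At this position, in this assay, putting 1,2-oxazol-3-yl in place of 4-cyanophenyl on an aromatic nitrogen gives a 29-fold higher number from compound 3 to compound 4 (1.46 log units; beyond the scatter) and so counts as a large loss. The low number of compound 3 therefore does not carry over to every aromatic ring on this nitrogen. No measurement at hand says what lies behind this step.

The compounds shown leave open whether the nitrile itself matters or the six-membered ring is enough. An unsubstituted phenyl or a 4-chlorophenyl on the same nitrogen would separate those two readings.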